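The source may hold more compounds than are shown below. What is called first, only, known or untested is meant among the compounds shown, and "the series" means these compounds.

Measured so far in a functional assay on HCT-116 cells (Homo sapiens) for cytotoxicity, read by MTT assay, with a stated time of 48 h; on this read-out lower numbers stand for stronger inhibition and higher numbers for weaker inhibition:
compound 1 `O=C(/C=C/c1ccc2c(c1)B(O)OC2)c1ccco1` — 24100 nM
compound 2 `Nc1ccc(C(=O)/C=C/c2ccc3c(c2)B(O)OC3)cc1` — 26100 nM
compound 3 `O=C(/C=C/c1ccc2c(c1)B(O)OC2)c1ccccc1O` — 77900 nM

Compound 1 gives the lowest number of the three; compound 2 sits within the scatter of it, whereas compound 3 lies beyond it. The step to compound 4 `Nc1cccc(C(=O)/C=C/c2ccc3c(c2)B(O)OC3)c1` is 3-aminophenyl in place of furan-2-yl on a carbonyl carbon. For the measured compounds named here, two measured steps bear on it. The first, a 1.1-fold higher number from compound 1 to compound 2 (0.03 log units; within the scatter), swaps furan-2-yl for 4-aminophenyl with no change beyond the scatter. The second, a 3.2-fold higher number from compound 1 to compound 3 (0.51 log units; beyond the scatter), swaps it for 2-hydroxyphenyl and costs a modest amount. The 4-aminophenyl case is the closer analogy, so for compound 4 in this assay no step beyond the scatter is expected, a 1.2-fold higher number from compound 1 to compound 4 (0.07 log units; within the scatter). Compound 4 is estimated at 28000 nM, range 12000 nM to 65000 nM.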

Compound 4, half-maximal inhibitory concentration: 4500 nM
Compound 4: middle estimate off by 6.2-fold (0.79 log units), on the high side; the measured number lies below the stated range.
By their numbers in this assay, from the lowest: compound 4; then compounds 1 and 2 (each within the scatter of the next); then compound 3.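

In this assay, the amine's place on the phenyl ring matters at this carbonyl carbon: 3-aminophenyl gives a clear shift from the 4-aminophenyl group (a 5.8-fold lower number from compound 2 to compound 4 (0.76 log units; beyond the scatter)), although 4-aminophenyl itself stayed within the scatter of furan-2-yl. For the compounds shown here, the 3-aminophenyl group also separates from furan-2-yl (a 5.4-fold lower number from compound 1 to compound 4 (0.73 log units; beyond the scatter)) and from 2-hydroxyphenyl (a 17-fold lower number from compound 3 to compound 4 (1.24 log units; beyond the scatter)), so this position responds more strongly than the earlier compounds indicated. No evidence is available to account for this shift. Still open, as far as these compounds go, is whether the lower number belongs to the amine itself or would carry over to an acetamide or a carboxylic acid in its place.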